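Swapping a pyridine for a pyrazine on the amide nitrogen

The source may hold more compounds than are shown below. What is called first, only, known or untested is meant among the compounds shown, and "the series" means these compounds.

Of the compounds shown here, three sharing one core have been measured in an assay on isolated protein for inhibition of phosphodiesterase 4A (Sus scrofa); a higher number here means a weaker inhibitor, a lower number a stronger inhibitor. Compound 1 `COc1ccc(C(=O)Nc2ccccc2F)cc1OC1CCCC1` gives 10700 nM, compound 2 `COc1ccc(C(=O)Nc2ccccc2Br)cc1OC1CCCC1` gives 130 nM, and compound 3 `COc1ccc(C(=O)Nc2ccccn2)cc1OC1CCCC1` gives 1000 nM. Among these three, compound 3 holds the second highest number: it lies an 11-fold lower number from compound 1 to compound 3 (1.03 log units; beyond the scatter) and a 7.7-fold higher number from compound 2 to compound 3 (0.89 log units; beyond the scatter), both beyond the scatter.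

Compound 4 `COc1ccc(C(=O)Nc2cnccn2)cc1OC1CCCC1` differs from compound 3 by pyrazin-2-yl in place of pyridin-2-yl on an amide-type nitrogen. Going by the values given here, no measured step shows this particular change. Among the compounds with values here, the two steps that touch the same spot, an 11-fold lower number from compound 1 to compound 3 (1.03 log units; beyond the scatter) and a 7.7-fold higher number from compound 2 to compound 3 (0.89 log units; beyond the scatter), show only that the group on the amide nitrogen can move this assay a great deal in either direction, and the step of an 82-fold lower number from compound 1 to compound 2 (1.92 log units; beyond the scatter) shows that even a single atom on that ring can matter strongly. Within the data shown here, with no closer precedent, only a modest change is expected, with a wide range; the step of a 1.5-fold higher number from compound 3 to compound 4 (0.18 log units; within the scatter) is the estimate. Compound 4 is therefore expected to give about 1500 nM in this assay, within a range of 300 nM to 7000 nM.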

Compound 4, half-maximal inhibitory concentration: 250 nM
The estimate for compound 4 lay 6.0-fold (0.78 log units) above the measured number, and the stated range ends above it.
By their numbers in this assay, from the lowest: compounds 2 and 4 (each within the scatter of the next); then compound 3; then compound 1.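

In this assay, pyrazin-2-yl in place of pyridin-2-yl gives a 4.0-fold lower number from compound 3 to compound 4 (0.60 log units; beyond the scatter), so one changed ring atom matters at this position even when the ring carries no halogen. The earlier compounds shown here had only 2-bromophenyl at the low end of the numbers, but a ring without a halogen now sits level with it: a 1.9-fold higher number from compound 2 to compound 4 (0.28 log units; within the scatter) lies within the scatter, so the two groups cannot be told apart in this assay. The step of a 43-fold lower number from compound 1 to compound 4 (1.63 log units; beyond the scatter) shows that 2-fluorophenyl stays far from both.

Nothing available gives a reason for these steps. The compounds shown leave open how a pyrimidin-2-yl group, or a phenyl ring carrying chloro or methyl, would read on the amide nitrogen, and whether the step from pyridin-2-yl to pyrazin-2-yl would hold on another core.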